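From Dimethylamino to Cyano: Expecting the Next Measurement

A few compounds are considered here, and "the series" means these few. Any claim that something is new, unique, unknown or untested is made for them only; others in the source may bear on it.

Of the compounds shown here, three sharing one core have been tested in a functional assay (muscle tissue) with Cavia porcellus as the target; a higher number here means that more compound is needed for the effect, a lower number that less compound is needed. Compound 1 `COC(=O)C1=C(C)N=C(C)/C(=C(\O)OC)C1c1cc(OC)c(OC)cc1OC` gives 1000000 nM, the highest number of the three. Compound 3 `COC(=O)C1=C(C)N=C(C)/C(=C(\O)OC)C1c1cc([N+](=O)[O-])ccc1O` gives 100 nM, the lowest. Compound 2 `COC(=O)C1=C(C)N=C(C)/C(=C(\O)OC)C1c1cccc(N(C)C)c1` sits second highest with 891 nM; its nearest neighbour is compound 3, whose lower number lies beyond the usual scatter, and compound 1 stands far above it, also beyond the scatter.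

The step of interest leads from compound 2 to compound 4 `COC(=O)C1=C(C)N=C(C)/C(=C(\O)OC)C1c1cccc(C#N)c1`, an untested compound. The change is cyano in place of dimethylamino on an aromatic carbon. Among the compounds with values here, no measured pair shows this exact change, so the size of the step can only be guessed from what the three measured compounds show. Since compound 3 reaches 100 nM with a different group on the same ring, a moderately lower number for compound 4 than for compound 2 is expected, a step of a 4.5-fold lower number from compound 2 to compound 4 (0.65 log units; beyond the scatter) in this assay. Compound 4 is therefore estimated at 200 nM, with a range from 50 nM to 800 nM.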

Compound 4, half-maximal effective concentration: 34.7 nM
Compound 4: the middle estimate sits 5.8-fold (0.76 log units) above what was measured, and the stated range ends above it.
By their numbers in this assay, from the lowest: compound 4; then compound 3; then compound 2; then compound 1.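

Putting cyano in place of dimethylamino on this aromatic carbon, meta to a large group, gives a 26-fold lower number from compound 2 to compound 4 (1.41 log units; beyond the scatter) in this assay, a large step. Within the data shown here, this is the first pair that differs in only one place, so it shows that this single exchange, with the rest of the molecule unchanged, can shift the required concentration substantially. Nothing available explains the size of this step.

One exchange cannot tell how much of the step comes from losing dimethylamino and how much from gaining cyano. On these data alone, it also remains open how a plain hydrogen, a chlorine atom, a primary amine or a carboxylic acid on the same carbon would compare, and whether the step would carry over to another place on the ring.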